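A Propylcarbamoyl Replacement and Its Expected Tolerance

The source may report more compounds than this note shows. Statements on the series, on what has been measured and on what is new or still open speak of the compounds shown alone.

Compound 1, `O=C(c1cc(F)c(F)cc1F)N(CCCCCCN1C[C@H](O)[C@@H](O)[C@H](O)[C@H]1CO)C1CCCCC1`; in an ADME assay on Huh-7 cells (Homo sapiens) for cytotoxicity, read by MTT assay (a lower number here means that less compound is tolerated, a higher number that more compound is tolerated), compound 1 gives > 500000 nM, a limit of the assay.
Compound 2, `CC(C)(C)S(=O)(=O)N(CCCCCCN1C[C@H](O)[C@@H](O)[C@H](O)[C@H]1CO)C1CCCCC1`; in this assay compound 2 gives > 500000 nM, again a limit.

Compound 2 therefore stands at the top of the measured range, with no number below the limit. Going by the values given here, the only measured step is a step that the two limits leave unreadable from compound 1 to compound 2, which cannot be sized because both values sit at the limit of > 500000 nM in this assay, at which 2 of the 2 values shown sit. Compound 3, `CCCNC(=O)N(CCCCCCN1C[C@H](O)[C@@H](O)[C@H](O)[C@H]1CO)C1CCCCC1`, differs from compound 2 by propylcarbamoyl in place of (tert-butyl)sulfonyl on an amine nitrogen. With no readable step to lean on, no shift beyond the scatter is expected. Compound 3 is expected at 500000 nM, within 200000 nM to 1000000 nM. This expectation amounts to a step of a number no higher from compound 2 to compound 3 (the limit leaves the size open).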

Compound 3, half-maximal cytotoxic concentration: > 500000 nM
Compound 3: a limit, no number (the forecaster's own chance of this, stated with the estimate: 80%); the middle value lies on the limit itself.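

Compound 3 also sits at a limit, so its steps from compound 1 and compound 2 cannot be read: the limit of > 500000 nM in this assay, at which 3 of the 3 values shown sit.

The compounds shown leave open whether any of these changes shifts the tolerated concentration in this assay.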